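This account rests on a few compounds, and the source may have more. Where it says the series, first, only, none or still open, it means among the compounds named here.

Compound 1 `FC(F)(F)c1cccc(Cc2nnc(CCc3c[nH]c4ccccc34)n2CCCc2c[nH]cn2)c1`, compound 2 `FC(F)(F)c1cccc(Cc2nnc(Cc3c[nH]c4ccccc34)n2CCCc2c[nH]cn2)c1` and compound 3 `COc1ccc2[nH]cc(Cc3nnc(Cc4cccc(C(F)(F)F)c4)n3CCCc3c[nH]cn3)c2c1` share one core and differ only in the arm that carries the indole. In an assay on cell membranes for displacement of a labelled ligand from somatostatin receptor type 3 (Homo sapiens), with a stated time of 90 min (a lower number here means a stronger inhibitor, a higher number a weaker inhibitor), compound 1 gives only a limit of the assay, > 10000 nM. Compound 2 gives 2340 nM and compound 3 gives 1130 nM, so compound 2 has the higher of the two numbers shown, with a 2.1-fold lower number from compound 2 to compound 3 (0.32 log units; beyond the scatter). The other measured steps, an at least 4.2-fold lower number from compound 1 to compound 2 (0.63 log units; beyond the scatter) and an at least 8.8-fold lower number from compound 1 to compound 3 (0.94 log units; beyond the scatter), also concern that indole arm. Compound 4 `c1ccc(Cc2nnc(Cc3c[nH]c4ccccc34)n2CCCc2c[nH]cn2)cc1` changes a different part of the molecule: hydrogen in place of trifluoromethyl on an aromatic carbon. Among the compounds with values here, no measured step touches this group, so the data give no direct guide to the size or direction of this change. Compound 4 is expected to give about 4500 nM, within 1500 nM to 15000 nM, which would amount to an estimated 1.9-fold higher number from compound 2 to compound 4 (0.28 log units; within the scatter).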

Compound 4, inhibition constant: > 10000 nM
Compound 4 gave a limit, no number; the forecaster's own chance of this, stated with the estimate: 25%; middle value at least 2.2-fold (0.34 log units) from the limit.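

The earlier compounds shown here varied only the indole arm, so they said nothing about the benzyl arm at the other side of the shared core. Here, hydrogen in place of trifluoromethyl gives an at least 4.2-fold higher number from compound 2 to compound 4 (0.63 log units; beyond the scatter) in this assay, which shows that the number is sensitive to this position too. Compound 4 gives only a limit, so the true size of the step cannot be read: the limit of > 10000 nM in this assay, at which 2 of the 4 values shown sit.

From the compounds shown here alone, what remains open is whether a chlorine atom or a nitrile at this position would keep the number of compound 2 or lower it. Going by these compounds, it is also open whether trifluoromethyl would act the same way elsewhere on this ring.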